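Naphthyl for Methylphenyl at the Sulfanyl Arm

The source may report more compounds than this note shows. Statements on the series, on what has been measured and on what is new or still open speak of the compounds shown alone.

Measured compounds in a functional assay on HeLa cells (Homo sapiens) for antiproliferative activity, read by MTT assay, with a stated time of 72 h; a lower number here means a stronger inhibitor, a higher number a weaker inhibitor:
- compound 1 `C/C(C#Cc1ccccc1)=N\N/C(N)=N/S(=O)(=O)c1cc(C)c(Cl)cc1SCc1cccc(C)c1`: 105000 nM
- compound 2 `Cc1cc(S(=O)(=O)/N=C(\N)N/N=C/C#Cc2ccccc2)c(SCc2ccc(C(F)(F)F)cc2)cc1Cl`: 93000 nM
- compound 3 `Cc1cc(S(=O)(=O)/N=C(\N)N/N=C/C#Cc2ccccc2)c(SCc2ccc(Cl)cc2)cc1Cl`: 6000 nM

Compound 1 gives the highest of the three numbers in this assay. Its nearest neighbour is compound 2, whose value lies within the scatter of that of compound 1, so no order between the two can be read. Within the data shown here, compound 3 stands far below both, and the single one-place step available is a 16-fold lower number from compound 2 to compound 3 (1.19 log units; beyond the scatter), a large step.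

Compound 4 `C/C(C#Cc1ccccc1)=N\N/C(N)=N/S(=O)(=O)c1cc(C)c(Cl)cc1SCc1cccc2ccccc12` is the unmeasured compound; it arises from compound 1 by the change (naphthalen-1-yl in place of 3-methylphenyl on a saturated chain carbon bound to a sulfur). The measured step from compound 2 to compound 3 concerns a different position on the sulfanyl-linked benzyl group and a shared core that also differs from that of compound 1 in the hydrazone part, so it does not bear on the change from compound 1 to compound 4. Among the measured compounds shown here, no measured step speaks to an exchange of 3-methylphenyl for naphthalen-1-yl. Compound 4 is therefore expected to show only a small shift, a 1.8-fold lower number from compound 1 to compound 4 (0.24 log units; within the scatter), not clearly beyond the scatter. Compound 4 is estimated at 60000 nM, with a range from 15000 nM to 150000 nM.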

Compound 4, half-maximal inhibitory concentration: 125000 nM
For compound 4 the middle estimate is 2.1-fold (0.32 log units) below the measured one; the measured number falls inside the stated range.
By their numbers in this assay, from the lowest: compound 3; then compounds 2, 1 and 4 (each within the scatter of the next).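

In this assay, naphthalen-1-yl in place of 3-methylphenyl on a saturated chain carbon bound to a sulfur gives a 1.2-fold higher number from compound 1 to compound 4 (0.08 log units; within the scatter) and so allows no order between the two compounds to be read. Among these compounds, this is the first reading of a change at this place on the core of compound 1: going from one six-membered aromatic ring to 2 leaves the number within the scatter. Nothing in the available data accounts for this result.

Going by these compounds, whether a pyridin-3-yl ring, or a 3-methylphenyl carrying an amine or a carboxylic acid, would shift the number at this place remains open. So does whether the same exchange would read alike on the core of compound 3, which differs in the hydrazone part.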